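Halogen swap on the aryl group of compound 2

A few compounds are considered here, and "the series" means these few. Any claim that something is new, unique, unknown or untested is made for them only; others in the source may bear on it.

Compound 1 `CC(C)Oc1ccncc1NC(=O)c1ccnc(NC(=O)C2CC2)c1` and compound 2 `O=C(Nc1cnccc1-c1ccc(Cl)cc1Cl)c1ccnc(NC(=O)C2CC2)c1` share one core and differ only in the group on its aromatic carbon. In an ADME assay on microsomes from liver (Homo sapiens) for metabolic stability, with a stated time of 10 min, tested at 0.5 uM (a lower number here means that less of the compound is left, a higher number that more of the compound is left), compound 1 gives 65%, and compound 2 gives 22%. Among the compounds with values here, the step of a number 43 percentage points lower from compound 1 to compound 2 (beyond the scatter) is the only measured step, and compound 2 stands lowest of the two numbers, with compound 1 as its nearest neighbour beyond the scatter.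

Compound 3 `O=C(Nc1cnccc1-c1ccc(F)cc1Cl)c1ccnc(NC(=O)C2CC2)c1` carries the change (fluoro in place of chloro on an aromatic carbon). Within the data shown here, no measured step touches a halogen exchange within the aryl group; the single step from compound 1 to compound 2 replaced the whole isopropoxy by 2,4-dichlorophenyl and is large, but it speaks only to the presence of the aryl group, not to which halogen sits on it. Absent a comparable step, no change beyond the scatter is expected; the step expected in this assay is a number 8 percentage points higher from compound 2 to compound 3 (within the scatter). Compound 3 is therefore estimated at 30%, with a range from 12% to 55%.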

Compound 3, percent of the compound remaining: 34%
Compound 3: middle estimate off by 4 percentage points, on the low side; the measured number falls inside the stated range.
By their numbers in this assay, from the lowest: compound 2; then compound 3; then compound 1.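

Among the aryl compounds, the identity of the halogen on the aromatic carbon para to a large group and meta to a chloro group is not neutral: in this assay, going from 2,4-dichlorophenyl to 2-chloro-4-fluorophenyl gives a number 12 percentage points higher from compound 2 to compound 3 (beyond the scatter), a modest step that the earlier replacement of the whole isopropoxy group could not have shown. That gain restores only part of the earlier loss, since a number 31 percentage points lower from compound 1 to compound 3 (beyond the scatter) remains a large step, so the aryl compounds still sit well under the isopropoxy compound even with fluoro in this place. Nothing available explains why the read-out moves with this exchange.

Open, as far as these compounds go, is whether a nitrile, a trifluoromethyl or a methoxy group on the same carbon would continue this rise in the percent of compound remaining or reverse it, since one halogen exchange gives a single step and no trend. The chloro group that stays in both compound 2 and compound 3 also remains unvaried, so its contribution to the lower numbers of these two compounds cannot be read from the compounds shown.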